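Swapping a carboxy chain for a tetrazolylbenzyl group

This account rests on a few compounds, and the source may have more. Where it says the series, first, only, none or still open, it means among the compounds named here.

Of the compounds shown here, three sharing one core have been tested in a toxicity assay on RMS13 cells (Homo sapiens) for inhibition, with a stated time of 24 h; on this read-out lower numbers stand for stronger inhibition of growth and higher numbers for weaker inhibition of growth. Compound 1 `CC1=C(C(=O)OCc2ccccc2)C(c2ccc(-c3ccccc3C)cc2)NC(=O)N1CCCCCc1nnn[nH]1` gives 100000 nM. Compound 2 `CC1=C(C(=O)OCc2ccccc2)C(c2ccc(-c3ccccc3)cc2)N(Cc2ccc(-c3nnn[nH]3)cc2)C(=S)N1` gives 72000 nM. Compound 3 `CC1=C(C(=O)OCc2ccccc2)C(c2ccc(-c3ccccc3)cc2)NC(=S)N1CCCCCC(=O)O` gives 100000 nM. On these numbers compound 3 stands level with compound 1, and its gap to compound 2 lies within the usual scatter, so the three values cannot be told apart in any reliable way.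

Compound 4 `CC1=C(C(=O)OCc2ccccc2)C(c2ccc(-c3ccccc3)cc2)NC(=S)N1Cc1ccc(-c2nnn[nH]2)cc1` has not yet been measured in this assay. Compared with compound 3 the change is 4-(1H-tetrazol-5-yl)phenyl in place of 4-carboxybutyl on a saturated chain carbon bound to an amide-type nitrogen in a ring. Compound 2 carries the same 4-(1H-tetrazol-5-yl)benzyl group, though on the other ring nitrogen, and its value of 72000 nM sits close to that of compound 3.

Among the compounds with values here, no step between measured compounds is available to guide the size of this change. Because compound 2 gives 72000 nM with the same entering group, compound 4 is expected to stay in the same weak range, with the step of a 1.2-fold lower number from compound 3 to compound 4 (0.07 log units; within the scatter) amounting to nothing beyond the scatter. The estimate for compound 4 is therefore 85000 nM, with a range from 40000 nM to 150000 nM.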

Compound 4, concentration for 50% growth inhibition: 87000 nM
Estimate against measurement, compound 4: 1.0-fold (0.01 log units) below, within the range that was stated.
By their numbers in this assay, from the lowest: compounds 2, 4, 1 and 3 (each within the scatter of the next).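

In this assay, placing 4-(1H-tetrazol-5-yl)phenyl in place of 4-carboxybutyl on a saturated chain carbon bound to an amide-type nitrogen in a ring gives a 1.1-fold lower number from compound 3 to compound 4 (0.06 log units; within the scatter). Within the data shown here, this is the first comparison here between two compounds that differ in only one place, and it shows that exchanging an open chain ending in a carboxylic acid for a group with two aromatic rings, one five-membered and one six-membered, leaves the read-out within the usual scatter of the measurement. No other measurement is at hand that could explain this lack of a clear shift.

What the compounds shown leave open is whether any group at this place can move the number beyond the scatter, for example a plain benzyl group, a chain ending in an amine, or a shorter chain ending in a carboxylic acid. As far as these compounds go, it is also open whether the same exchange would give a similar result on a core carrying a carbonyl where compound 3 and compound 4 carry a thiocarbonyl.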